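The source may hold more compounds than are shown below. What is called first, only, known or untested is meant among the compounds shown, and "the series" means these compounds.

Measured so far in a functional assay on MDA-MB-231 cells (Homo sapiens) for cytotoxicity, read by MTT assay, with a stated time of 72 h; on this read-out higher numbers stand for weaker inhibition and lower numbers for stronger inhibition:
compound 1 `Cc1cc(/C=C/c2ccc(O)cc2)[nH]n1`, 23200 nM
compound 2 `COc1ccc(/C=C/c2cc(C)n[nH]2)cc1`, 10700 nM
compound 3 `COc1ccc(/C=C/c2cc(C)no2)cc1`, 69300 nM

Compound 2 and compound 3 share the side chain but not the core; the difference between the two cores is not broken down here. Compound 3 carries the highest number of the three; its nearest neighbour is compound 1 and its furthest is compound 2, both steps beyond the scatter.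

One change is seen twice. From compound 2 to compound 1 it is hydrogen in place of methyl on an oxygen on an aromatic ring, and it gave a 2.2-fold higher number from compound 2 to compound 1 (0.34 log units; beyond the scatter). From compound 3 to compound 4 `Cc1cc(/C=C/c2ccc(O)cc2)on1` the same change is made: hydrogen in place of methyl on an oxygen on an aromatic ring.

Since the two place lines agree word for word, a step of the same sign and similar size is expected from compound 3 to compound 4, resting on the step from compound 2 to compound 1 a 2.2-fold higher number from compound 2 to compound 1 (0.34 log units; beyond the scatter); it is estimated as a 2.2-fold higher number from compound 3 to compound 4 (0.34 log units; beyond the scatter). Compound 4 is thus expected at 150000 nM, within 70000 nM to 320000 nM.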

Compound 4, half-maximal inhibitory concentration: 55500 nM
Estimate against measurement, compound 4: 2.7-fold (0.43 log units) above, and the stated range ends above it.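

On the other core, the change from methoxy to hydroxy gives a 1.2-fold lower number from compound 3 to compound 4 (0.10 log units; within the scatter), so the step seen on the core of compound 2 does not carry over. In this assay, the outcome of this change differs between the two cores: the same change on two cores in this assay, a 2.2-fold higher number (0.34 log units; beyond the scatter) from compound 2 to compound 1 and a 1.2-fold lower number (0.10 log units; within the scatter) from compound 3 to compound 4, 2.7-fold (0.43 log units) apart, beyond the scatter of two such steps

These two pairs show that the step cannot be assumed to hold from one core to the other in this series, but they do not show why the cores differ or what the change would do on a further core.

Open, from the compounds shown here alone, is whether an amine or a carboxylic acid in place of the hydroxy would follow either step. Also open, going by these compounds, is how a longer chain on that oxygen would read on each core.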